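The compounds below may be only part of what the source reports. "The series", "measured", "known", "first", "only" and "open" are said of these compounds alone.

Measured so far, in a functional assay on RCC4 cells (Homo sapiens) for antiproliferative activity, read by XTT assay, with a stated time of 48 h; a higher number here means a weaker inhibitor, a lower number a stronger inhibitor:

compound 1 `CC(=O)OC[C@H]1O[C@@H](n2cc(CN(c3ccc(C)cc3)S(=O)(=O)c3ccccc3)nn2)[C@H](OC(C)=O)[C@@H](OC(C)=O)[C@@H]1OC(C)=O`; in this assay compound 1 gives 130000 nM
compound 2 `CS(=O)(=O)N(Cc1cn([C@@H]2O[C@H](CO)[C@@H](O)[C@H](O)[C@H]2O)nn1)c1ccc(C#N)cc1`; in this assay compound 2 gives 200000 nM

Compound 2 holds the higher of the two numbers, but its nearest neighbour, compound 1, stands within the usual scatter of it, so the two are to be read as level: both sit at the weak end of what this assay resolves. For the measured compounds named here, the two compounds differ in several places at once, so no single-change step can be taken from them and nothing in the set says how a change at the sugar alone moves the number.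

Compound 3 `CS(=O)(=O)N(Cc1cn([C@@H]2O[C@H](CO)[C@@H](O[C@H]3O[C@H](CO)[C@@H](O)[C@H](O)[C@H]3O)[C@H](O)[C@H]2O)nn1)c1ccc(C#N)cc1` is the next candidate. Against compound 2 the change is 3,4,5-trihydroxy-6-(hydroxymethyl)oxan-2-yl in place of hydrogen on an oxygen on a saturated carbon. The shared core and the sulfonamide arm are kept unchanged.

Going by the values given here, with no measured step to lean on, the expectation rests on the level at which compound 2 stands, 200000 nM, and on the size of the added group. The expected step is a 1.2-fold higher number from compound 2 to compound 3 (0.06 log units; within the scatter), that is, nothing beyond the scatter, with some chance the assay returns only a limit. Compound 3 is estimated at 230000 nM, within a range of 100000 nM to 550000 nM.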

Compound 3, half-maximal inhibitory concentration: 250000 nM
Compound 3: middle estimate off by 1.1-fold (0.04 log units), on the low side, and the stated range covers the measured number.
By their numbers in this assay, from the lowest: compounds 1, 2 and 3 (each within the scatter of the next).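

In this assay, for the compounds shown here, the first single-change step reads a 1.3-fold higher number from compound 2 to compound 3 (0.10 log units; within the scatter), so 3,4,5-trihydroxy-6-(hydroxymethyl)oxan-2-yl in place of hydrogen on an oxygen on a saturated carbon gives no change that can be told from the scatter. This position therefore accepts a substituent of this size, carrying one more six-membered non-aromatic ring, with the number staying level, although at a level where a further loss would be hard to read and where a flat step says little about how sensitive the position is. No measurement at hand bears on the reason for this flat step.

As far as these compounds go, whether an amine, a carboxylic acid or a longer chain in place of hydrogen on that oxygen would move the number beyond the scatter stays open, and so does whether any group there could bring the series away from the weak end of this assay. Also open, from the compounds shown here alone, is whether the sulfonamide arm, kept unchanged in this step, sets the level, which a carboxylic acid in place of its nitrile would test.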